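This account rests on a few compounds, and the source may have more. Where it says the series, first, only, none or still open, it means among the compounds named here.

Measured so far:
Compound 1 `CC1SC(c2cccc(C(=O)NCCCCc3ccccc3)c2)N(c2ccc(C3CC3)cc2)C1=O`: 10000 nM
Compound 2 `Cc1ccnc(N2C(=O)CSC2c2cccc(C(=O)NCCCCn3cccn3)c2)c1`: 50000 nM
Compound 3 `O=C(NCCCCc1ccccc1)c1cccc(C2SCC(=O)N2c2cccc(-c3c[nH]nn3)c2)c1`: 20000 nM

All three compounds were read in a physicochemical assay for solubility, read by turbidimetry, measured as kinetic solubility, at pH 6.8; on this read-out higher numbers stand for higher solubility and lower numbers for lower solubility. Compound 3 stands within the scatter of compound 1, while compound 2 reads higher than compound 3 by a gap beyond the scatter. No two of the three differ in one place only, so no single change has a measured size here.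

Compound 4 `CC(F)(F)c1cccc(N2C(=O)CSC2c2cccc(C(=O)NCCCCc3ccccc3)c2)c1` keeps the amide side chain of compound 3 and changes one group: 1,1-difluoroethyl in place of 1H-1,2,3-triazol-4-yl on an aromatic carbon. The closest measured comparison is compound 1, which shares that side chain, carries no 1H-1,2,3-triazol-4-yl and gives 10000 nM. Compound 1 also differs from compound 4 elsewhere, so this comparison is only a loose guide. On that basis, a modest fall is expected in this assay, with a wide margin of doubt. The estimated change is a 2.5-fold lower number from compound 3 to compound 4 (0.40 log units; beyond the scatter). For compound 4 the expected value is 8000 nM, with an estimated range from 3000 nM to 20000 nM.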

Compound 4, solubility: 10000 nM
For compound 4 the middle estimate is 1.3-fold (0.10 log units) below the measured one; measured number inside the range.
By their numbers in this assay, from the lowest: compounds 1, 4 and 3 (each within the scatter of the next); then compound 2.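

Among these compounds, this is the first step in the set that differs in one place, and in this assay it reads a 2.0-fold lower number from compound 3 to compound 4 (0.30 log units; within the scatter), so the two compounds cannot be told apart on this read-out. The step puts 1,1-difluoroethyl in place of 1H-1,2,3-triazol-4-yl on an aromatic carbon of a six-membered aromatic ring of carbon only, meta to a large group, so a five-membered aromatic ring with its hydrogen-bond donor and acceptors gives way to a group with no ring, donors or acceptors, and no difference beyond the scatter appears at this position. No measured property of either group bears on this result, so the step stands without an explanation.

From the compounds shown here alone, it remains open whether an amine or a carboxylic acid on this same aromatic carbon would stand apart from compound 3 by more than the scatter. Also open, going by these compounds, is whether 1,1-difluoroethyl and 1H-1,2,3-triazol-4-yl would stay as close with another amide side chain, such as a longer chain.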